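Four analogs in a leukemia cell growth assay

The source may report more compounds than this note shows. Statements on the series, on what has been measured and on what is new or still open speak of the compounds shown alone.

Measured:
Compound 1 `CN(C)c1ncnc2c1c(-c1ccoc1)cn2[C@@H]1O[C@H](CO)[C@@H](O)[C@H]1O`: 13300 nM in a functional assay on CCRF-CEM cells (Homo sapiens), read by MTT assay, with a stated time of 72 h; on this read-out higher numbers stand for weaker inhibition and lower numbers for stronger inhibition
Compound 2 `CSc1ncnc2c1c(-c1ccoc1)cn2[C@@H]1O[C@H](CO)[C@@H](O)[C@H]1O`: 14200 nM in this assay
Compound 3 `CSc1ncnc2c1c(-c1cccs1)cn2[C@@H]1O[C@H](CO)[C@@H](O)[C@H]1O`: only a limit, > 20000 nM, in this assay

Compound 3 sits at the limit of > 20000 nM in this assay, at which 1 of the 3 values shown sits, so no number is known for it.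

From compound 2 to compound 1 the change is dimethylamino in place of methylsulfanyl on an aromatic carbon; it made a 1.1-fold lower number from compound 2 to compound 1 (0.03 log units; within the scatter).

The cores of compound 2 and compound 3 differ by thiophen-2-yl in place of furan-3-yl on an aromatic carbon; this gave an at least 1.4-fold higher number from compound 2 to compound 3 (0.14 log units; that floor lies within the scatter).

Compound 4 `CN(C)c1ncnc2c1c(-c1cccs1)cn2[C@@H]1O[C@H](CO)[C@@H](O)[C@H]1O` is not yet measured. It differs from compound 3 by dimethylamino in place of methylsulfanyl on an aromatic carbon, the same change as from compound 2 to compound 1, at the same place.

For compound 4 the expected step is a step that the limit leaves unreadable from compound 3 to compound 4; this rests on compound 2 to compound 1 giving a 1.1-fold lower number from compound 2 to compound 1 (0.03 log units; within the scatter), a step within the scatter. Compound 4 is therefore estimated at 25000 nM, between 12000 nM and 50000 nM.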

Compound 4, half-maximal inhibitory concentration: > 20000 nM
Compound 4 gave a limit, no number; the forecaster's own chance of this, stated with the estimate: 60%; the middle value is on the limit's open side.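

In this assay compound 4 gives only a limit, > 20000 nM, so the dimethylamino in place of methylsulfanyl step on the thiophen-2-yl core cannot be read, and whether that change carries over from the furan-3-yl core is not shown. Thiophen-2-yl in place of furan-3-yl gives an at least 1.5-fold higher number from compound 1 to compound 4 (0.17 log units; that floor lies within the scatter), and beside the earlier step the two cores can be compared only this far: the same change on two cores in this assay, an at least 1.4-fold higher number (0.14 log units; that floor lies within the scatter) from compound 2 to compound 3 and an at least 1.5-fold higher number (0.17 log units; that floor lies within the scatter) from compound 1 to compound 4; the limit leaves it open whether they differ Neither step shows a size beyond the scatter, and the thiophen-2-yl compounds give no number to work from: the limit of > 20000 nM in this assay, at which 2 of the 4 values shown sit.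

Still open, from the compounds shown here alone, is how far the thiophen-2-yl compounds lie past the limit. Also open, going by these compounds, is what a methoxy group or a longer alkyl chain would give on that aromatic carbon, or a phenyl ring in place of furan-3-yl.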